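Compound 3: a chain stereocentre drawn without configuration

The source may hold more compounds than are shown below. What is called first, only, known or untested is meant among the compounds shown, and "the series" means these compounds.

In a functional assay on SW480 cells (Homo sapiens) for antiproliferative activity, read by MTT assay, with a stated time of 48 h (on this read-out higher numbers stand for weaker inhibition and lower numbers for stronger inhibition), compound 1 (`CCCCCCCC(CCO)n1cnc2c(Cl)ncnc21`) gives 3630 nM and compound 2 (`CCCCCCCCC[C@@H](CCO)n1cnc2c(Cl)ncnc21`) gives 3620 nM on the same measure. Compound 2 therefore stands level with compound 1, the two values lying within the scatter of each other.

Compound 3 (`CCCCCCCCCC(CCO)n1cnc2c(Cl)ncnc21`) differs from compound 2 in one respect (the two compounds have the same atoms and bonds; at least one stereo element is drawn with a configuration in one of them and without one in the other: 1 of 1 stereo elements differ; a stereocentre at a saturated chain carbon is drawn S in compound 2 and without a configuration in compound 3): the two compounds have the same atoms and bonds, and a stereocentre at a saturated chain carbon is drawn S in compound 2 and without a configuration in compound 3.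

Among the compounds with values here, no step between measured compounds is available to size this change, and no compound drawn with the opposite configuration has been measured. With atoms and bonds unchanged, compound 2 at 3620 nM is the natural reference, and no shift beyond the scatter is expected in this assay for compound 3. The expected 1.0-fold higher number from compound 2 to compound 3 (0.01 log units; within the scatter) stays inside the scatter. For compound 3 the estimated value is 3700 nM with an expected range from 2200 nM to 6000 nM (an estimate, not yet a measurement).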

Compound 3, half-maximal inhibitory concentration: 1150 nM
Compound 3: middle estimate off by 3.2-fold (0.51 log units), on the high side, outside the stated range (below it).
By their numbers in this assay, from the lowest: compound 3; then compounds 2 and 1 (each within the scatter of the next).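

In this assay, the stereocentre at the saturated chain carbon is now shown to matter to the read-out: with atoms and bonds unchanged, the move gives a 3.1-fold lower number from compound 2 to compound 3 (0.50 log units; beyond the scatter), a modest step that the level pair of compound 1 and compound 2 gave no hint of. Ethyl in place of hydrogen on a saturated chain carbon, eight bonds along the chain from an aromatic nitrogen, gives a 3.2-fold lower number from compound 1 to compound 3 (0.50 log units; beyond the scatter), so compound 3 holds the lowest number of the three, while compound 1 and compound 2 stay level, and chain extension alone therefore does not account for the gain, since compound 2 carries the same chain as compound 3. The structures offer only one difference to set against the first step, and it concerns the drawing of the stereocentre, not the connectivity: the fact that one of compounds 2 and 3 is drawn with a defined configuration and the other without, at the place where they differ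

As far as these compounds go, what the opposite configuration, drawn as such, would give stays open, as does the make-up of compound 3 at this stereocentre, so the step cannot yet be assigned to one configuration. Also open, from the compounds shown here alone, is the effect of a longer chain, of a carboxylic acid in place of the hydroxyl, or of an amine in place of the chlorine.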